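A few compounds are considered here, and "the series" means these few. Any claim that something is new, unique, unknown or untested is made for them only; others in the source may bear on it.

In a functional assay on U-87MG ATCC cells for antiproliferative activity against U-87 MG (Homo sapiens), read by MTT assay, with a stated time of 48 h, tested at 50 uM (a lower number here means a stronger effect, a higher number a weaker effect of the compound at the concentration tested), the measured compounds gave the following:
compound 1 `Cc1nc(-c2ccc(Cl)cc2)sc1C(=O)CSc1nc(-c2ccccc2)c(C#N)c(=O)[nH]1`: 41.6%
compound 2 `COc1cccc(-c2nc(SCC(=O)c3sc(-c4ccccc4)nc3C)[nH]c(=O)c2C#N)c1`: 80.3%
compound 3 `Cc1nc(-c2ccc(Cl)cc2)sc1C(=O)CSc1nc(-c2cccc(Cl)c2)c(C#N)c(=O)[nH]1`: 52.6%

Compound 3 stands second highest of the three numbers. The step of a number 11 percentage points higher from compound 1 to compound 3 (beyond the scatter) is modest but beyond the scatter, while compound 2 lies further away with 80.3%.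

Compound 4 `Cc1nc(-c2ccccc2)sc1C(=O)CSc1nc(-c2cccc(Cl)c2)c(C#N)c(=O)[nH]1` differs from compound 3 by hydrogen in place of chloro on an aromatic carbon. Among the measured compounds shown here, the only measured step, a number 11 percentage points higher from compound 1 to compound 3 (beyond the scatter), concerns chloro in place of hydrogen on an aromatic carbon elsewhere in the molecule; no measured pair varies the 4-chlorophenyl itself. Nothing therefore points to a step beyond the scatter, and the estimated change is a number 0.6 percentage points lower from compound 3 to compound 4 (within the scatter). Compound 4 is accordingly expected at 52%, with a range from 35% to 70%.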

Compound 4, a percentage reported as activity, at one concentration (the size of the read-out at that concentration, not a potency): 50.6%
Beside the measured number, compound 4's estimate is 1.4 percentage points above it, and the stated range covers the measured number.
By their numbers in this assay, from the lowest: compounds 1, 4 and 3 (each within the scatter of the next, the first and the last beyond it); then compound 2.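

In this assay, the change from 4-chlorophenyl to phenyl gives a number 2 percentage points lower from compound 3 to compound 4 (within the scatter), so the chloro at this place, para to a large group, can be removed without a shift that stands out from the scatter. Chloro in place of methoxy, at another place in the molecule, gives a number 29.7 percentage points lower from compound 2 to compound 4 (beyond the scatter), which is beyond the scatter. No evidence on why either step has its size is available here.

Going by these compounds, it remains open how an amine or a carboxylic acid at the para place would read. On these data alone, it also remains open whether the methoxy to chloro step holds when the 4-chlorophenyl is present.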